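The source may hold more compounds than are shown below. What is called first, only, known or untested is meant among the compounds shown, and "the series" means these compounds.

Of the compounds shown here, two sharing one core have been measured so far in an ADME assay on cells (Homo sapiens) for cytotoxicity, read by polymerase chain reaction, with a stated time of 3 days; on this read-out higher numbers stand for lower toxicity in this test and lower numbers for higher toxicity in this test. Here compound 1 `Nc1nc(Cl)c(-c2nc3ccccc3s2)c(N[C@@H]2C[C@H](CO)[C@@H](O)[C@H]2O)n1` gives 14000 nM, and compound 2 `Nc1nc(Cl)c(-c2nc3ccc(Cl)cc3s2)c(N[C@@H]2C[C@H](CO)[C@@H](O)[C@H]2O)n1` gives 16000 nM. These two numbers lie within the usual scatter of repeated measurements, so compound 2 stands level with compound 1.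

Compound 3 `CCOc1ccc2nc(-c3c(Cl)nc(N)nc3N[C@@H]3C[C@H](CO)[C@@H](O)[C@H]3O)sc2c1` is the next to be tested. Its change from compound 2 is ethoxy in place of chloro on an aromatic carbon.

For the measured compounds named here, only one measured step bears on this change. That step, a 1.1-fold higher number from compound 1 to compound 2 (0.06 log units; within the scatter), put chloro in place of hydrogen on the same aromatic carbon. It is a single step and involves a different group, so it is only a loose guide. Still, it gives no reason to expect a real shift, and nothing measured points in either direction. No step beyond the scatter is therefore expected in this assay.

The expected step is a 1.1-fold lower number from compound 2 to compound 3 (0.03 log units; within the scatter). For compound 3 the estimated value is 15000 nM, with an expected range from 7000 nM to 32000 nM.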

Compound 3, half-maximal cytotoxic concentration: > 25000 nM
Compound 3 gave a limit, no number; the forecaster's own chance of this, stated with the estimate: 15%; middle value at least 1.6-fold (0.22 log units) away from the limit.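

In this assay, compound 3 gives a limit of the assay and not a number: the limit of > 25000 nM in this assay, at which 1 of the 3 values shown sits. Putting ethoxy in place of chloro gives an at least 1.5-fold higher number from compound 2 to compound 3 (0.19 log units; that floor lies within the scatter), while putting ethoxy in place of hydrogen gives an at least 1.7-fold higher number from compound 1 to compound 3 (0.25 log units; that floor lies within the scatter). The earlier compounds shown here showed only chloro and hydrogen on this aromatic carbon, so the new information is that ethoxy, with its 3 heavy atoms and its hydrogen-bond acceptor, can sit here with no sign of higher toxicity in this test, although neither floor shows a real rise.

Going by these compounds, the true value of compound 3 stays open, as it could lie close to its limit or far past it, so the real size of both steps is unknown and a shift beyond the scatter can be neither claimed nor ruled out. The compounds shown also leave open how an amine, a carboxylic acid or a chain longer than ethoxy on this same aromatic carbon would read in this assay.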